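This account rests on a few compounds, and the source may have more. Where it says the series, first, only, none or still open, it means among the compounds named here.

In a functional assay on HeLa cells (Homo sapiens) for antiproliferative activity, with a stated time of 5 days (on this read-out lower numbers stand for stronger inhibition and higher numbers for weaker inhibition), compound 1 `COc1ccc(-n2nc(-c3ccc4ccccc4c3)nc2N2C(=O)COC23C=CC(=O)C=C3)cc1` gives 200 nM, compound 2 `O=C1C=CC2(C=C1)OCC(=O)N2c1nc(-c2ccc3ncccc3c2)nn1-c1ccccc1` gives 110 nM and compound 3 `COc1ccc(-n2nc(-c3ccc4ccccc4c3)nc2N2C(=O)C(C)OC23C=CC(=O)C=C3)cc1` gives 140 nM. Compound 1 therefore stands within the scatter of both other compounds, and these numbers show no real separation from it. Compound 4 `O=C1C=CC2(C=C1)OCC(=O)N2c1nc(-c2ccc3ccccc3c2)nn1-c1ccc(C(F)(F)F)cc1` keeps the core of compound 1 and makes a single change: trifluoromethyl in place of methoxy on an aromatic carbon, para to a large group.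

For the measured compounds named here, the only measured step in one place, a 1.4-fold lower number from compound 1 to compound 3 (0.15 log units; within the scatter), concerns a saturated ring carbon rather than this position, so it bears on the change only indirectly. Compound 2 has no methoxy but also differs elsewhere, and its 110 nM says little about this swap alone. Going by the values given here, no measured compound carries trifluoromethyl, so the range must stay wide. The expected change is a 1.1-fold higher number from compound 1 to compound 4 (0.04 log units; within the scatter), which means no step beyond the scatter is expected in this assay. For compound 4 the estimated value is 220 nM, with an expected range from 80 nM to 600 nM.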

Compound 4, half-maximal inhibitory concentration: 390 nM
For compound 4 the middle estimate is 1.8-fold (0.25 log units) below the measured one; the range from low to high includes it.
By their numbers in this assay, from the lowest: compounds 2, 3, 1 and 4 (each within the scatter of the next, the first and the last beyond it).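

For the compounds shown here, this is the first direct reading of this position: on the aromatic carbon para to a large group, the swap from 4-methoxyphenyl to 4-(trifluoromethyl)phenyl gives a 2.0-fold higher number from compound 1 to compound 4 (0.29 log units; within the scatter) in this assay. The read-out therefore stays measurable and close to that of compound 1, even though the entering group has more heavy atoms and, unlike methoxy, counts no hydrogen-bond acceptor. Nothing available offers an explanation for the size of this step.

On these data alone, a single pair cannot show how far this position can be varied, and an amine, a carboxylic acid or a longer chain such as ethoxy in the same place remains open. As far as these compounds go, whether the same swap would give a similar step on compound 2 or compound 3 also remains open.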